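The source may hold more compounds than are shown below. What is called first, only, known or untested is meant among the compounds shown, and "the series" means these compounds.

In a functional assay on K562 cells (Homo sapiens) for inhibition, read by MTT assay, with a stated time of 48 h (a higher number here means a weaker inhibitor, a lower number a stronger inhibitor), compound 3 (`Nc1nc2ccc(-c3cn([C@@H]4CN[C@H](C(=O)Nc5ccc(Cl)c(C(F)(F)F)c5)C4)nn3)nc2s1`) gives 26200 nM, the highest number of the three measured and so the weakest inhibitor here. Compound 1 (`O=C(Nc1ccc(-c2cn([C@@H]3CN[C@H](C(=O)Nc4ccc(Cl)c(C(F)(F)F)c4)C3)nn2)cn1)C1CC1`) gives 8770 nM and compound 2 (`Nc1n[nH]c2cc(-c3cn([C@@H]4CN[C@H](C(=O)Nc5ccc(Cl)c(C(F)(F)F)c5)C4)nn3)ccc12`) gives 8320 nM. These two are level, as a 1.1-fold lower number from compound 1 to compound 2 (0.02 log units; within the scatter) lies within the scatter.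

Compound 4 (`CC(=O)Nc1nc2ccc(-c3cn([C@@H]4CN[C@H](C(=O)Nc5ccc(Cl)c(C(F)(F)F)c5)C4)nn3)nc2s1`) differs from compound 3 by acetyl in place of hydrogen on a nitrogen on an aromatic ring, or amino to acetamido.

Among the measured compounds shown here, no measured pair isolates this change, so the evidence is indirect. The 6-((cyclopropylcarbonyl)amino)pyridin-3-yl group of compound 1 carries an acylated amino group, while the 3-amino-1H-indazol-6-yl group of compound 2 carries a free one, and the two compounds do not separate. Both a 3.0-fold higher number from compound 1 to compound 3 (0.48 log units; beyond the scatter) and a 3.1-fold higher number from compound 2 to compound 3 (0.50 log units; beyond the scatter) are modest, which sets a rough upper size for a step in this small series. An acylated amino group therefore gives no sign of a penalty, and a small move towards a lower number is expected, probably not clearing the scatter.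

The step expected in this assay is a 1.6-fold lower number from compound 3 to compound 4 (0.21 log units; within the scatter). For compound 4 the estimated value is 16000 nM, with an expected range of 6000 nM to 40000 nM.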

Compound 4, half-maximal inhibitory concentration: 10000 nM
Compound 4: the middle estimate sits 1.6-fold (0.20 log units) above what was measured, within the range that was stated.
By their numbers in this assay, from the lowest: compounds 2, 1 and 4 (each within the scatter of the next); then compound 3.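

In this assay, among the compounds shown here, the amino to acetamido change gives a 2.6-fold lower number from compound 3 to compound 4 (0.42 log units; beyond the scatter) and is the only direct reading so far of a change on this nitrogen on an aromatic ring: acetyl in place of hydrogen is tolerated here and moves the number down, modestly but beyond the scatter. Compound 4 at 10000 nM stands within the scatter of compound 1 and compound 2, which leaves compound 3 alone as the high number of the four in this small set. No measured property of these compounds bears on this step, so the data offer no explanation for it.

Going by these compounds, whether the step depends on the carbonyl or simply on replacing the hydrogen stays open: a methyl group or a methanesulfonyl group on this nitrogen would separate the two, and a cyclopropylcarbonyl group here would show whether a larger acyl group carries the step further. Also open, on these data alone, is whether acetyl on the amino group of compound 2 would move the number in the same direction, or whether the step belongs to the core of compound 3 alone.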